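Swapping the Aryl Group on the Amide Nitrogen

The compounds below may be only part of what the source reports. "The series", "measured", "known", "first", "only" and "open" are said of these compounds alone.

Three compounds sharing one core, each carrying an acid chain and an amide, have been tested in a functional assay on CHO cells for agonist activity at Free fatty acid receptor 1 (Homo sapiens), read by calcium flux; on this read-out lower numbers stand for an effect already at smaller amounts and higher numbers for an effect only at larger amounts of compound. Compound 2 `O=C(O)CCc1ccc(OCc2nnc(C(=O)Nc3ccccc3F)s2)cc1` gives 580 nM. Compound 1 `Cc1cccc(-c2cccc(NC(=O)c3nnc(CCC(=O)O)s3)c2)c1` gives 760 nM, and compound 3 `COc1cccc(NC(=O)c2nnc(COc3ccc(CCC(=O)O)cc3)s2)c1` gives 4680 nM. Compound 2 shows the lowest of the three numbers, though its gap to compound 1 lies within the scatter, while compound 3 sits clearly beyond it.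

The new compound 4 `Cc1ccc(NC(=O)c2nnc(COc3ccc(CCC(=O)O)cc3)s2)cc1` differs from compound 2 in one place: 4-methylphenyl in place of 2-fluorophenyl on an amide-type nitrogen.

For the measured compounds named here, only one measured step changes that same position: an 8.1-fold higher number from compound 2 to compound 3 (0.91 log units; beyond the scatter). Going by the values given here, that step went toward higher numbers, and it is the only direct guide here. Among the compounds with values here, compound 4 brings in yet another group, so the direction cannot simply be copied; compound 1 carries a different arrangement altogether, and no step between it and the others is drawn. Within the data shown here, a moderate rise in the number is expected, smaller than the one seen for compound 3, although a result within the scatter of compound 2 cannot be ruled out.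

Compound 4 is therefore estimated at 1500 nM, with a range from 500 nM to 5000 nM, which is expected to correspond to a 2.6-fold higher number from compound 2 to compound 4 (0.41 log units; beyond the scatter).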

Compound 4, half-maximal effective concentration: 4300 nM
Compound 4: the middle estimate sits 2.9-fold (0.46 log units) below what was measured; the range from low to high includes it.
By their numbers in this assay, from the lowest: compounds 2 and 1 (each within the scatter of the next); then compounds 4 and 3 (each within the scatter of the next).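

In this assay, a second replacement of the 2-fluorophenyl on the amide-type nitrogen shifts the number much as the first did: a 7.4-fold higher number from compound 2 to compound 4 (0.87 log units; beyond the scatter), set against the earlier 8.1-fold higher number from compound 2 to compound 3 (0.91 log units; beyond the scatter). The two replacements themselves are not told apart, even though 4-methylphenyl and 3-methoxyphenyl are different groups, since the result is a 1.1-fold lower number from compound 3 to compound 4 (0.04 log units; within the scatter). The higher number is therefore no longer tied to a single group, and among these three groups on this nitrogen, 2-fluorophenyl stands alone with the lowest number, although nothing available here explains why.

As far as these compounds go, what remains open is whether that lower number goes with the fluorine atom itself or with where the group carries it, a question that 2-methylphenyl, 4-fluorophenyl and plain phenyl on the same nitrogen could help settle. It is also unknown whether the same swap would behave alike with a longer chain in place of the acid chain, or with an amine on the aromatic ring.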